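The compounds below may be only part of what the source reports. "The series", "measured", "known", "first", "only" and "open" are said of these compounds alone.

In a functional assay on HT-1080 cells (Homo sapiens) for cytotoxicity, read by MTT assay, with a stated time of 72 h (on this read-out lower numbers stand for stronger inhibition and higher numbers for weaker inhibition), three compounds built on a shared core have been measured so far: compound 1 `COc1ccc(/C=C2\CCC/C(=C\c3cccc(OC)c3OC)C2=O)cc1` gives 16300 nM, compound 2 `COc1cccc(/C=C2\CCC/C(=C\c3cc(Cl)cc(Cl)c3)C2=O)c1OC` gives 6100 nM, and compound 3 `COc1ccc(/C=C2\CCC/C(=C\c3ccc(Cl)cc3)C2=O)cc1OC` gives 4800 nM. The numbers for compound 3 and compound 2 lie within the usual scatter of each other, so they cannot be told apart, and both stand clearly under the number for compound 1.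

Compound 4 `COc1ccc(/C=C2\CCC/C(=C\c3ccc(OC)c(OC)c3)C2=O)cc1` is reached from compound 3 by a single change: methoxy in place of chloro on an aromatic carbon. In words, methoxy takes the place of chloro on an aromatic carbon, para to a large group, so 4-chlorophenyl becomes 4-methoxyphenyl.

Among the measured compounds shown here, only one measured step bears on this change. It is a 2.7-fold lower number from compound 1 to compound 2 (0.43 log units; beyond the scatter), a modest step beyond the scatter, in which 3,5-dichlorophenyl replaced 4-methoxyphenyl. The new change runs the opposite way, from a chlorinated ring to a methoxylated one, and it involves one chloro rather than two. A single step is thin evidence, but it points to a higher number in this assay, of similar or somewhat smaller size.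

The estimated change is a 2.1-fold higher number from compound 3 to compound 4 (0.32 log units; beyond the scatter). For compound 4 the expected value is 10000 nM, with an estimated range from 4500 nM to 22000 nM.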

Compound 4, half-maximal inhibitory concentration: 7200 nM
The estimate for compound 4 lay 1.4-fold (0.14 log units) above the measured number, and the stated range covers the measured number.
By their numbers in this assay, from the lowest: compounds 3, 2 and 4 (each within the scatter of the next); then compound 1.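

In this assay, putting methoxy in place of chloro on this aromatic carbon gives a 1.5-fold higher number from compound 3 to compound 4 (0.18 log units; within the scatter), so at this position the two groups cannot be told apart. The earlier step, a 2.7-fold lower number from compound 1 to compound 2 (0.43 log units; beyond the scatter), was beyond the scatter, but it replaced a whole 4-methoxyphenyl with 3,5-dichlorophenyl and so could not isolate one substituent; this pair does, and it shows that, with the rest of compound 3 held fixed, the chloro is not needed to keep the number within the scatter. Nothing shown here explains why these two groups read alike.

The compounds shown cover only chloro and methoxy at this position, so it remains open whether a group of another kind, such as an amine, a carboxylic acid or a longer chain like butoxy, would also leave the number within the scatter or move it clearly. From the compounds shown here alone, it is also open whether the same swap would read alike with different groups on the other ring, since this single pair tests it against only one partner.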